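Removing the methyl from the ring nitrogen

This account rests on a few compounds, and the source may have more. Where it says the series, first, only, none or still open, it means among the compounds named here.

Compound 1 `Cn1c(-c2cccnc2)nc2ccc(F)cc21` gives 677 nM in an assay on V79 cells for inhibition of cytochrome P450 11B1, mitochondrial (Homo sapiens), read by HTRF, with a stated time of 1 h; on this read-out lower numbers stand for stronger inhibition and higher numbers for weaker inhibition.
Compound 2 `CS(=O)(=O)c1ccc2c(c1)nc(-c1cccnc1)n2C1CC1` gives > 10000 nM in this assay, which is a limit of the assay rather than a number.

Compound 1 therefore holds the only number shown in this assay. Going by the values given here, for compound 2 the assay reports only (the limit of > 10000 nM in this assay, at which 1 of the 2 values shown sits), so no step between the two measured compounds can be stated, and there is no measured step of any kind to lean on. Compound 3 `Fc1ccc2nc(-c3cccnc3)[nH]c2c1` differs from compound 1 by hydrogen in place of methyl on an aromatic nitrogen. With no measured change of this kind shown, the size of the shift it brings in this assay is open; a modest shift is expected, more likely toward weaker than toward stronger inhibition, but the range also allows no change beyond the usual scatter. Compound 3 is accordingly estimated at 1500 nM, with a range from 300 nM to 7000 nM. The step this estimate means, a 2.2-fold higher number from compound 1 to compound 3 (0.35 log units; beyond the scatter), is expected to be small.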

Compound 3, half-maximal inhibitory concentration: 1990 nM
For compound 3 the middle estimate is 1.3-fold (0.12 log units) below the measured one; the measured number falls inside the stated range.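

In this assay, the aromatic nitrogen of the five-membered ring now has its first measured step: hydrogen in place of methyl gives a 2.9-fold higher number from compound 1 to compound 3 (0.47 log units; beyond the scatter), a modest move toward weaker inhibition. The earlier compounds shown here could not show this, as they offered one number and one limit and no pair differing in a single place. The methyl therefore goes with the stronger inhibition in this pair, yet compound 3 without it still gives a number rather than a limit, so the group is not needed for measurable inhibition on this core, and nothing measured here accounts for the size of the shift.

This is one pair on one core, so it leaves open whether the same change would give a similar step with other groups elsewhere on the core. It also leaves open how this nitrogen responds to anything beyond hydrogen and methyl in a single-place comparison, such as an ethyl group, a longer chain ending in an amine, or a chain carrying a carboxylic acid.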